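Demethylation in a Pyrazole Urea Series: Expecting Another Limit

The source may hold more compounds than are shown below. What is called first, only, known or untested is meant among the compounds shown, and "the series" means these compounds.

Compound 1 `O=C(Nc1cccc(-n2cc(-c3ccncc3)c(-c3ccc(Cl)c(O)c3)n2)c1)Nc1cccc(C(F)(F)F)c1`: > 32500 nM
Compound 2 `O=C(Nc1cccc(-n2cc(-c3ccncc3)c(-c3ccc(Cl)c(O)c3)n2)c1)Nc1ccc(Cl)c(Cl)c1`: > 32500 nM
Compound 3 `COc1cc(-c2nn(-c3cccc(NC(=O)Nc4ccc(Cl)c(C(F)(F)F)c4)c3)cc2-c2ccncc2)ccc1Cl`: > 32500 nM

In a functional assay on K562 cells (Homo sapiens) for inhibition, read by sulforhodamine B assay, with a stated time of 48 h (on this read-out lower numbers stand for stronger inhibition of growth and higher numbers for weaker inhibition of growth), compound 1 gives > 32500 nM, which is a limit of the assay and not a number. Compound 2 gives > 32500 nM, again a limit. Compound 3 gives > 32500 nM, also a limit. For the measured compounds named here, all three values therefore sit at the limit of > 32500 nM in this assay, at which 3 of the 3 values shown sit, and the only single-point comparison, a step that the two limits leave unreadable from compound 1 to compound 2, has no readable size.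

Compound 4 `O=C(Nc1cccc(-n2cc(-c3ccncc3)c(-c3ccc(Cl)c(O)c3)n2)c1)Nc1ccc(Cl)c(C(F)(F)F)c1` differs from compound 3 by hydrogen in place of methyl on an oxygen on an aromatic ring. Going by the values given here, compound 1 and compound 2 already carry the hydroxy form, and both sit at the same limit as compound 3, so no measured step gives a readable size for this change in this assay; nothing in the data points to growth inhibition below the limit after this change.

Compound 4 is therefore expected to give about 50000 nM in this assay, within a range from 20000 nM to 150000 nM. The implied step, a step that the limit leaves unreadable from compound 3 to compound 4, is estimated to stay unreadable behind the limit, with no expected shift beyond the usual scatter.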

Compound 4, concentration for total growth inhibition: > 32500 nM
Compound 4 was reported as a limit; the forecaster's own chance of this, stated with the estimate: 85%; the middle value does not contradict the limit.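

In this assay compound 4 gives > 32500 nM, a limit of the assay and not a number. The steps joining compound 4 to compound 1, compound 2 and compound 3 therefore cannot be read: the limit of > 32500 nM in this assay, at which 4 of the 4 values shown sit.

The compounds shown leave open whether methoxy to hydroxy, or any other change among them, shifts growth inhibition at all in this assay.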